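N-Methylation in the dioxane series: a second test

The compounds below may be only part of what the source reports. "The series", "measured", "known", "first", "only" and "open" are said of these compounds alone.

Compound 1 `CNCC[C@@H]1CCOC(c2ccccc2)(c2ccccc2)O1` and compound 2 `CN(C)CC[C@@H]1CCOC(c2ccccc2)(c2ccccc2)O1` share the core of compound 1 and differ only in methyl in place of hydrogen on an amine nitrogen. In an assay for displacement of a labelled ligand from Sigma non-opioid intracellular receptor 1 (Cavia porcellus), read by scintillation counting (a higher number here means a weaker inhibitor, a lower number a stronger inhibitor), compound 1 gives > 10000 nM, which is a limit of the assay and not a number. In this assay compound 2 gives 660 nM, so that the step is an at least 15-fold lower number from compound 1 to compound 2 (1.18 log units; beyond the scatter); how far it truly reaches is open, since the starting point is the limit of > 10000 nM in this assay, at which 1 of the 3 values shown sits.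

Compound 3 `CNCCC[C@@H]1CCO[C@H](c2ccccc2)O1` carries a different core; the difference between the two cores is not broken down here. In this assay compound 3 gives 327 nM, which sits within the scatter of compound 2.

Compound 4 `CN(C)CCC[C@@H]1CCO[C@H](c2ccccc2)O1` is not yet measured. It differs from compound 3 by methyl in place of hydrogen on an amine nitrogen, the same change as that from compound 1 to compound 2, at an identically described place. On the evidence of compound 2 relative to compound 1, a lower number is expected for compound 4, with the step from compound 3 estimated as a 3.0-fold lower number from compound 3 to compound 4 (0.47 log units; beyond the scatter). Compound 4 is expected to give about 110 nM, between 30 nM and 450 nM.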

Compound 4, inhibition constant: 1220 nM
The estimate for compound 4 lay 11-fold (1.04 log units) below the measured number, outside the stated range (above it).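

In this assay, methyl in place of hydrogen on an amine nitrogen gives a 3.7-fold higher number from compound 3 to compound 4 (0.57 log units; beyond the scatter), so the change did not keep its direction when carried from one core to the other: the same change on two cores in this assay, an at least 15-fold lower number (1.18 log units; beyond the scatter) from compound 1 to compound 2 and a 3.7-fold higher number (0.57 log units; beyond the scatter) from compound 3 to compound 4, at least 56-fold (1.75 log units) apart, beyond the scatter of two such steps Compound 1 gives > 10000 nM, which is a limit and not a number, so the earlier step has no fixed size: the limit of > 10000 nM in this assay, at which 1 of the 4 values shown sits. The two pairs differ in their cores as well as in this change, and the data do not show which part of the core difference goes with the reversal, nor can two pairs set a rule for the series.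

Left open is which direction the same change takes on any further core, and whether the result for either pair extends beyond these four compounds. Also open, going by these compounds, is how an ethyl group on the same nitrogen, or an amide in place of the amine, would read on either core.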